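This account rests on a few compounds, and the source may have more. Where it says the series, first, only, none or still open, it means among the compounds named here.

Measured so far in a physicochemical assay for solubility, read by HPLC, in phosphate buffer, with a stated time of 24 h, at 37 degrees C, at pH 5.5 (a lower number here means a less soluble compound, a higher number a more soluble compound), are:
- compound 1 `Nc1cc(OCCNc2ccnc3cc(Cl)ccc23)nc(N)n1` with 300 nM as its reading
- compound 2 `CC(COc1cc(N)nc(N)n1)Nc1ccnc2cc(Cl)ccc12` with 1450 nM as its reading

Compound 2 holds the higher of the two numbers, and its gap to compound 1 lies beyond the scatter. Compound 3 `CCC(COc1cc(N)nc(N)n1)Nc1ccnc2cc(Cl)ccc12` is compound 2 with one change, (methyl in place of hydrogen on a saturated chain carbon, two bonds along the chain from a nitrogen on an aromatic ring), which reads methyl to ethyl when cut one bond further out. Going by the values given here, the only measured step bearing on this is a 4.8-fold higher number from compound 1 to compound 2 (0.68 log units; beyond the scatter) for methyl in place of hydrogen on a saturated chain carbon bound to a nitrogen on an aromatic ring, modest in size. That single step lies at another place on the chain, so no step beyond the scatter is expected in this assay and neither direction is favoured. The estimate is a 1.0-fold higher number from compound 2 to compound 3 (0.01 log units; within the scatter) as the expected step. Compound 3 is expected at 1500 nM, with an estimated range from 500 nM to 4000 nM as a working figure.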

Compound 3, solubility: 40 nM
Compound 3: middle estimate off by 38-fold (1.57 log units), on the high side; measured number below the stated range.
By their numbers in this assay, from the lowest: compound 3; then compound 1; then compound 2.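

Notes on the chain carbon: in this assay the methyl to ethyl change at this place, on a saturated chain carbon, two bonds along the chain from a nitrogen on an aromatic ring, gives a 36-fold lower number from compound 2 to compound 3 (1.56 log units; beyond the scatter) and is the largest step in the series so far. Against the unbranched chain, ethyl gives a 7.5-fold lower number from compound 1 to compound 3 (0.88 log units; beyond the scatter) while methyl gives a 4.8-fold higher number from compound 1 to compound 2 (0.68 log units; beyond the scatter) in the opposite direction, so the effect of substitution at this carbon does not run one way and does not scale simply with one added carbon. No measurement shown accounts for this reversal.

The compounds shown leave open whether a longer chain such as propyl at this carbon reads lower still or levels off. They also leave open how a hydroxyl or an amine at the end of the ethyl group would read.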